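Aryl amide swap on the shared core: compound 3 to compound 4

The source may hold more compounds than are shown below. What is called first, only, known or untested is meant among the compounds shown, and "the series" means these compounds.

Compound 3 `NC(=O)c1cccc(C(=O)N2CCC(N(C3CC3)S(=O)(=O)c3cccc(C(F)(F)F)c3)CC2)c1` gives "not determined" (no result reported) in an assay on cells for inhibition of Voltage-dependent L-type calcium channel subunit alpha-1C (Homo sapiens), read by FLIPR and calcium flux, tested at 3 uM; a higher number here means a stronger effect of the compound at the concentration tested, a lower number a weaker effect; no single number stands for it there. Compound 1 `O=C(c1cccc(OC(F)(F)F)c1)N1CCC(N(C2CC2)S(=O)(=O)c2cccc(C(F)(F)F)c2)CC1` gives 78% in this assay and compound 2 `NC(=O)c1ccccc1C(=O)N1CCC(N(C2CC2)S(=O)(=O)c2cccc(C(F)(F)F)c2)CC1` gives 17%. Among the compounds with values here, the one measured step, a number 61 percentage points lower from compound 1 to compound 2 (beyond the scatter), bears on the present change in reverse, since a carbamoylphenyl is again exchanged against a trifluoromethoxyphenyl. Compound 4 `O=C(c1ccc(OC(F)(F)F)cc1)N1CCC(N(C2CC2)S(=O)(=O)c2cccc(C(F)(F)F)c2)CC1` differs from compound 3 by 4-(trifluoromethoxy)phenyl in place of 3-carbamoylphenyl on a carbonyl carbon. Given the large step from compound 1 to compound 2, a large gain in this assay is expected on going from compound 3 to compound 4, although compound 3 itself is unmeasured and the trifluoromethoxy group in compound 4 sits at a different position from that in compound 1. Compound 4 is therefore estimated at 65%, with a range of 35% to 90%.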

Compound 4, a percentage reported as inhibition, at one concentration (the size of the read-out at that concentration, not a potency): 88%
Estimate against measurement, compound 4: 23 percentage points below; low and high end bracket the measured number.
By their numbers in this assay, from the lowest: compound 2; then compounds 1 and 4 (each within the scatter of the next).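

In this assay, the 4-(trifluoromethoxy)phenyl group on the carbonyl carbon stands well clear of the 2-carbamoylphenyl group (a number 71 percentage points higher from compound 2 to compound 4 (beyond the scatter)). Exchanging the 3-(trifluoromethoxy)phenyl group for the 4-(trifluoromethoxy)phenyl group separates nothing (a number 10 percentage points higher from compound 1 to compound 4 (within the scatter)), so these two groups cannot be told apart here. No data bearing on the cause of either step are available.

The step from compound 3 to compound 4 cannot be read, so the 3-carbamoylphenyl group stays unplaced. As far as these compounds go, whether a phenyl group carrying a carboxylic acid or an amine behaves like the 2-carbamoylphenyl group remains open.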